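This account rests on a few compounds, and the source may have more. Where it says the series, first, only, none or still open, it means among the compounds named here.

Working notes on the series. Compound 1 `O=S1(=O)C=Cc2ccc(Nc3ccc(Cl)cc3)cc21` gives 2300 nM in a functional assay on A549 cells (Homo sapiens) for antiproliferative activity, read by MTT assay, with a stated time of 72 h; a lower number here means a stronger inhibitor, a higher number a weaker inhibitor. Compound 2 `O=S1(=O)C=Cc2ccc(Nc3ccc(Cl)c(Cl)c3)cc21` carries chloro in place of hydrogen on an aromatic carbon and in this assay compound 2 gives 3320 nM, the step being a 1.4-fold higher number from compound 1 to compound 2 (0.16 log units; within the scatter). Compound 3 `O=S1(=O)C=Cc2cccc(Nc3ccc(Cl)cc3)c21` has the same atoms as compound 1 joined differently; the difference between the two cores is not broken down here. In this assay compound 3 gives 1040 nM, the lowest of the three numbers, beyond the scatter from both compound 1 and compound 2. Compound 4 `O=S1(=O)C=Cc2cccc(Nc3ccc(Cl)c(Cl)c3)c21` awaits measurement and carries chloro in place of hydrogen on an aromatic carbon, the same change as from compound 1 to compound 2, occurring twice among the compounds shown. Because a 1.4-fold higher number from compound 1 to compound 2 (0.16 log units; within the scatter) lies within the scatter, the change is expected to give a 1.4-fold higher number from compound 3 to compound 4 (0.14 log units; within the scatter) in this assay. The estimate for compound 4 is therefore 1450 nM, with a range from 700 nM to 3000 nM.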

Compound 4, half-maximal inhibitory concentration: 660 nM
Estimate against measurement, compound 4: 2.2-fold (0.34 log units) above; measured number outside the range, below it.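

In this assay the added chloro gives a 1.6-fold lower number from compound 3 to compound 4 (0.20 log units; within the scatter), and the steps on the two cores do not separate: the same change on two cores in this assay, a 1.4-fold higher number (0.16 log units; within the scatter) from compound 1 to compound 2 and a 1.6-fold lower number (0.20 log units; within the scatter) from compound 3 to compound 4, 2.3-fold (0.36 log units) apart, within the scatter of two such steps. The opposite directions of the two steps carry no weight, and on both cores the change stays within the scatter. This does not show that the two cores respond identically, as each step rests on a single pair of compounds and a small real difference could go unseen.

The compounds shown leave open whether a group other than chloro, such as a methoxy group, an amine or a carboxylic acid, would behave alike on both cores. As far as these compounds go, whether a step beyond the scatter would carry from one core to the other also remains open.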